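Pentyl to nitro at the aryl substituent of the hydantoin series

This account rests on a few compounds, and the source may have more. Where it says the series, first, only, none or still open, it means among the compounds named here.

Of the compounds shown here, two of the shared core have numbers so far. Compound 1 `CCN(CC)c1ccc(N2C(=O)NC3(CSC4=C3C(=O)c3ncccc3C4=O)C2=O)cc1` carries a diethylamino group on the aromatic carbon and in a functional assay on MCF7 cells (Homo sapiens) for antiproliferative activity, read by MTT assay, with a stated time of 96 h (on this read-out higher numbers stand for weaker inhibition and lower numbers for stronger inhibition), compound 1 gives 30 nM. Compound 2 `CCCCCc1ccc(N2C(=O)NC3(CSC4=C3C(=O)c3ncccc3C4=O)C2=O)cc1` carries pentyl in that position and in this assay compound 2 gives 250 nM. For the measured compounds named here, the one measured step is an 8.3-fold higher number from compound 1 to compound 2 (0.92 log units; beyond the scatter), so compound 2 stands at the higher of the two numbers and is the weaker inhibitor of the pair.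

Compound 3 `O=C1C2=C(C(=O)c3ncccc31)C1(CS2)NC(=O)N(c2ccc([N+](=O)[O-])cc2)C1=O` is the next member. The change from compound 2 is nitro in place of pentyl on an aromatic carbon. Going by the values given here, no measured step exchanges pentyl for nitro, and the only step in hand, an 8.3-fold higher number from compound 1 to compound 2 (0.92 log units; beyond the scatter), replaces diethylamino with pentyl; it shows that the group on this aromatic carbon can move the number well beyond the scatter, but it does not tell in which direction a nitro group would move it from compound 2. The expectation for compound 3 is therefore a step of a 1.2-fold higher number from compound 2 to compound 3 (0.08 log units; within the scatter) in this assay, with a range wide enough to hold a shift either way. Compound 3 is estimated at 300 nM, between 60 nM and 1500 nM.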

Compound 3, half-maximal inhibitory concentration: 350 nM
Beside the measured number, compound 3's estimate is 1.2-fold (0.07 log units) below it, within the range that was stated.
By their numbers in this assay, from the lowest: compound 1; then compounds 2 and 3 (each within the scatter of the next).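

In this assay there is a 1.4-fold higher number from compound 2 to compound 3 (0.15 log units; within the scatter) so pentyl and nitro show no readable difference on this aromatic carbon, even though an all-carbon chain gives way to a group that holds hydrogen-bond acceptors. Diethylamino now stands apart from both of these groups: there is a 12-fold higher number from compound 1 to compound 3 (1.07 log units; beyond the scatter) alongside an 8.3-fold higher number from compound 1 to compound 2 (0.92 log units; beyond the scatter) and both steps lie beyond the scatter, which makes compound 1 the strongest inhibitor of these three. The series therefore reads as one low number for the diethylamino compound and two numbers within the scatter of each other for pentyl and nitro, and no measurement at hand accounts for that split.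

On these data alone, whether the low number belongs to diethylamino alone or extends to other amines stays open, and dimethylamino or a piperidine ring on this aromatic carbon would test that. Also open, as far as these compounds go, is whether a hydroxyl group or a carboxylic acid in this place would read like pentyl and nitro or like diethylamino.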